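The source may report more compounds than this note shows. Statements on the series, on what has been measured and on what is new or still open speak of the compounds shown alone.

In an ADME assay on MDBK cells (Bos taurus) for cytotoxicity, read by MTT assay, with a stated time of 96 h (on this read-out lower numbers stand for higher toxicity in this test and higher numbers for lower toxicity in this test), compound 3 `CN(/N=N/c1ccccc1)c1ccccc1` gives > 100000 nM, which is a limit and not a number. Compound 1 `Cc1ccc(/N=N/N(C)c2ccccc2)cc1` gives > 100000 nM, also a limit. Compound 2 `Fc1ccc(F)c(/N=N/c2ccc(NC[C@@H]3CCCN4CCCC[C@H]34)c3c2CCCC3)c1`, a very different structure, gives a true number of 64000 nM. Compound 3 therefore sits with compound 1 at the limit of > 100000 nM in this assay, at which 2 of the 3 values shown sit. Compound 4 `CN(/N=N/c1cccc([N+](=O)[O-])c1)c1ccccc1` has nitro in place of hydrogen on an aromatic carbon, meta to a large group: nitro in place of hydrogen on an aromatic carbon. For the measured compounds named here, the only measured step nearby is a step that the two limits leave unreadable from compound 1 to compound 3, a swap of hydrogen for methyl, so it offers no size to carry over. The expected change is an at least 1.4-fold lower number from compound 3 to compound 4 (0.15 log units; that floor lies within the scatter), a modest move toward higher toxicity in this assay at the very most, and compound 4 may well stay at the limit. Compound 4 is estimated at 70000 nM, within a range from 20000 nM to 100000 nM.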

Compound 4, half-maximal cytotoxic concentration: 82000 nM
Compound 4: the middle estimate sits 1.2-fold (0.07 log units) below what was measured; measured number inside the range.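

In this assay, for the compounds shown here, nitro on an aromatic carbon, meta to a large group, gives the only step here with a readable size: an at least 1.2-fold lower number from compound 3 to compound 4 (0.08 log units; that floor lies within the scatter). This is only a floor, and compound 3 has no true number, so the real size of the change may be larger. The step between compound 1 and compound 3 cannot be read, and the limit remains common: the limit of > 100000 nM in this assay, at which 2 of the 4 values shown sit.

From the compounds shown here alone, whether an amine or a carboxylic acid on the same aromatic carbon would give a true number stays open. Going by these compounds, the size of any such change also stays open.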